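The source may report more compounds than this note shows. Statements on the series, on what has been measured and on what is new or still open speak of the compounds shown alone.

Measured so far in an assay on isolated protein for inhibition of histone deacetylase 4 (Homo sapiens), with a stated time of 1 h; a lower number here means a stronger inhibitor, a higher number a weaker inhibitor:

Compound 1, `CCOc1ccc2nc(NC(=O)COc3ccc4cc(/C=C5/SC(=O)NC5=O)ccc4c3)sc2c1`, gives 3600 nM.
Compound 2, `O=C(COc1ccc2cc(/C=C3/SC(=O)NC3=O)ccc2c1)Nc1ccc(Br)cc1F`, gives 1900 nM.
Compound 3, `O=C(COc1ccc2ccccc2c1/C=C1\SC(=O)NC1=O)Nc1ccc([N+](=O)[O-])cc1`, gives 15000 nM.

Among these three, compound 2 shows the lowest number. Compound 1 lies within the usual scatter of compound 2, so the two cannot be told apart; compound 3 lies well beyond it. Compound 4, `O=C(COc1ccc2cc(/C=C3/SC(=O)NC3=O)ccc2c1)Nc1ccc(F)cc1F`, has not yet been measured in this assay. It differs from compound 2 in one place: fluoro in place of bromo on an aromatic carbon. Going by the values given here, no measured pair here shows what fluoro in place of bromo does, so the expectation rests on the swap being a single atom exchange on the same ring. The step from compound 2 is expected to be small, probably toward a slightly higher number but within the scatter, a 1.5-fold higher number from compound 2 to compound 4 (0.17 log units; within the scatter). Compound 4 is therefore estimated at 2800 nM, with a range from 1200 nM to 6500 nM.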

Compound 4, half-maximal inhibitory concentration: 3900 nM
Beside the measured number, compound 4's estimate is 1.4-fold (0.14 log units) below it; the measured number falls inside the stated range.
By their numbers in this assay, from the lowest: compounds 2, 1 and 4 (each within the scatter of the next, the first and the last beyond it); then compound 3.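

In this assay, going by these compounds alone, the change from 4-bromo-2-fluorophenyl to 2,4-difluorophenyl gives the first step that can be read between compounds differing in one place: a 2.1-fold higher number from compound 2 to compound 4 (0.31 log units; beyond the scatter). The step is modest, but it shows that the number responds to the atom at this position, para to a large group, with fluoro giving the higher number. No measurement available here explains this difference.

As far as these compounds go, whether a chloro, a methoxy group or an amine at this position would give a lower or higher number remains open. So does whether removing the remaining fluoro would shift the number at all.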